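Inverting One Ring Stereocentre of Compound 3

The source may report more compounds than this note shows. Statements on the series, on what has been measured and on what is new or still open speak of the compounds shown alone.

Of the compounds shown here, three sharing one core have been measured in a functional assay on HT-29 cells (Homo sapiens) for cytotoxicity, read by resazurin assay, with a stated time of 48 h; on this read-out higher numbers stand for weaker inhibition and lower numbers for stronger inhibition. Compound 1 `COc1cc(O)c2c(=O)cc(-c3ccc(O)cc3)oc2c1[C@H]1C[C@H](O)[C@H](O)[C@@H](C)O1` gives 26000 nM. Compound 2 `COc1cc(O)c2c(=O)cc(-c3ccc(O)cc3)oc2c1[C@H]1CC(=O)[C@H](O)[C@@H](C)O1`, which carries a different group of 9 heavy atoms on an aromatic carbon, gives 11600 nM; the change brought a 2.2-fold lower number from compound 1 to compound 2 (0.35 log units; beyond the scatter). Compound 3 `C[C@H]1O[C@@H](c2c(O)cc(O)c3c(=O)cc(-c4ccc(O)cc4)oc23)C[C@H](O)[C@@H]1O`, with hydrogen in place of methyl on an oxygen on an aromatic ring, gives 25300 nM; that replacement gave a 1.0-fold lower number from compound 1 to compound 3 (0.01 log units; within the scatter). Compound 3 thus stands second highest of the three numbers, within the scatter of compound 1 and separated only from compound 2.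

Compound 4 `C[C@H]1O[C@@H](c2c(O)cc(O)c3c(=O)cc(-c4ccc(O)cc4)oc23)C[C@H](O)[C@H]1O` has not yet been measured. (the two compounds have the same atoms and bonds and differ only in configuration as drawn: 1 of 4 stereo elements differ; a stereocentre at a saturated ring carbon is drawn S in compound 3 and R in compound 4). Neither measured step touches this kind of change: the step from compound 1 to compound 2 exchanged one ring group for another, and the step from compound 1 to compound 3 removed a methyl. Within the data shown here, no measured pair compares two configurations of the same atoms and bonds. With nothing in the data pointing in either direction, the step expected for compound 4 is a 1.0-fold lower number from compound 3 to compound 4 (0.01 log units; within the scatter), and it is expected to remain within the scatter. Compound 4 is accordingly estimated at 25000 nM, with a range from 11000 nM to 55000 nM.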

Compound 4, half-maximal inhibitory concentration: 10000 nM
Beside the measured number, compound 4's estimate is 2.5-fold (0.40 log units) above it; measured number below the stated range.
By their numbers in this assay, from the lowest: compounds 4 and 2 (each within the scatter of the next); then compounds 3 and 1 (each within the scatter of the next).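

In this assay, inverting one stereocentre at a saturated ring carbon from S to R gave a 2.5-fold lower number from compound 3 to compound 4 (0.40 log units; beyond the scatter), so this position responds to configuration alone. The earlier steps shown here changed atoms and bonds, and one of them, a 1.0-fold lower number from compound 1 to compound 3 (0.01 log units; within the scatter), stayed within the scatter; neither could show that a change in the drawn configuration, with the same atoms and bonds, can move the number beyond the scatter. The step can be assigned to this single stereocentre because nothing else separates the pair: the fact that compounds 3 and 4 differ only in the configuration as drawn

The compounds shown leave open whether the same inversion would give a step of similar size and direction with methyl on the oxygen on the aromatic ring, as in compound 1, or with the ring group of compound 2, and how the three other stereo elements would behave if inverted. They also leave open what an amine or a fluorine in place of a hydroxyl on this saturated ring would do to the number, and they say nothing about why the R configuration gives the lower number.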